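A few compounds are considered here, and "the series" means these few. Any claim that something is new, unique, unknown or untested is made for them only; others in the source may bear on it.

Measured in a functional assay on WiDr cells (Homo sapiens) for inhibition, read by sulforhodamine B assay, with a stated time of 48 h; a higher number here means a weaker inhibitor of growth, a lower number a stronger inhibitor of growth:
- Compound 1 `Cc1cc(=O)oc2cc(N=C=[Se])ccc12`: 4800 nM
- Compound 2 `COC(=[Se])Nc1ccc2c(C)cc(=O)oc2c1`: > 100000 nM

Compound 2 reads > 100000 nM, and this is a limit of this assay, not a number. It is therefore known only as the weaker of the two compounds, with no exact place on the scale.

Compound 3 `CCOC(=[Se])Nc1ccc2c(C)cc(=O)oc2c1` has one small difference from compound 2, methyl in place of hydrogen on a saturated chain carbon bound to an oxygen on an unsaturated carbon, so that methoxy becomes ethoxy.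

Going by the values given here, only one measured step exists, an at least 20-fold higher number from compound 1 to compound 2 (1.31 log units; beyond the scatter). It is large, but it exchanges a different pair of groups, so it does not show what this smaller change does. Among the compounds with values here, no measured pair tests methoxy against ethoxy, which makes any forecast uncertain.

The expectation rests on compound 2, whose reading > 100000 nM is a limit. The expected change is a number no higher from compound 2 to compound 3 (the limit leaves the size open), meaning no shift beyond the scatter. Compound 3 is estimated at 100000 nM, with an expected range of 30000 nM to 200000 nM, and it too may be reported only as a limit.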

Compound 3, concentration for 50% growth inhibition: > 100000 nM
Compound 3: only a limit was reported; the forecaster's own chance of this, stated with the estimate: 65%; the middle value lies on the limit itself.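

In this assay compound 3 reads > 100000 nM and this is a limit, not a number. Carrying ethoxy instead of methoxy does not bring back the growth inhibition of compound 1: the comparison gives an at least 20-fold higher number from compound 1 to compound 3 (1.31 log units; beyond the scatter) and so the large step first seen with the methoxy group of compound 2 appears again with a second chain. The step between compound 2 and compound 3 cannot be read, so methoxy and ethoxy cannot be ranked, since both compounds stand at the same boundary of the scale: the limit of > 100000 nM in this assay, at which 2 of the 3 values shown sit.

As far as these compounds go, how far beyond this limit compound 2 and compound 3 truly lie remains open, and so does the size of any effect of adding the methyl group. Also open, from the compounds shown here alone, is whether a longer chain, such as butoxy, or an amine in place of the ethoxy group would give a reading on the scale.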